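The compounds below may be only part of what the source reports. "The series", "measured", "known", "first", "only" and "open" are said of these compounds alone.

Measured so far in an in vitro ADME assay on microsomes from liver (Homo sapiens) for metabolic stability, tested at 5 uM; on this read-out lower numbers stand for a shorter-lived compound and higher numbers for a longer-lived compound:

compound 1, `CC(C)CCn1nc(-c2ccccc2)c(O)c(C2=NS(=O)(=O)c3cc(NS(C)(=O)=O)ccc3N2)c1=O`, 0.633 h
compound 2, `CCC(C)(C)Cn1nc(-c2cccs2)c(O)c(C2=NS(=O)(=O)c3cc(NS(C)(=O)=O)ccc3N2)c1=O`, > 1 h

Compound 1 gives a plain number in this assay. Within the data shown here, for compound 2 the reading is a limit of the assay and not a number, as the line the limit of > 1 h in this assay, at which 1 of the 2 values shown sits, states; it tells only that compound 2 sits at the long-lived edge of what this assay reports. Among the measured compounds shown here, since one of the two values is a limit, the gap between compound 1 and compound 2 cannot be set in size, and no single-change step between them is available.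

Compound 3, `CCC(C)n1nc(-c2cccs2)c(O)c(C2=NS(=O)(=O)c3cc(NS(C)(=O)=O)ccc3N2)c1=O`, shares the core and the thiophen-2-yl group of compound 2 and differs in one place: sec-butyl in place of 2,2-dimethylbutyl on an aromatic nitrogen. Both the group that leaves and the group that enters are plain alkyl chains without rings, donors or acceptors, so the change is a shortening of the chain on that aromatic nitrogen and nothing more.

For the measured compounds named here, with no measured single-change step to rely on, the expected movement from compound 2 is modest, an at least 1.1-fold lower number from compound 2 to compound 3 (0.04 log units; that floor lies within the scatter), possibly toward a somewhat shorter half-life but not clearly beyond the scatter. Compound 3 is estimated at 0.9 h, in a range from 0.4 h to 2 h.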

Compound 3, half-life: > 1 h
Compound 3: a limit, no number; the forecaster's own chance of this, stated with the estimate: 40%; middle value at least 1.1-fold (0.04 log units) away from the limit.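

Compound 2 and compound 3 both read as a limit and not a number in this assay, so the step from 2,2-dimethylbutyl to sec-butyl on the aromatic nitrogen cannot be read: the limit of > 1 h in this assay, at which 2 of the 3 values shown sit.

The compounds shown leave open how long either half-life really is, and whether exchanging these two chains changes it at all.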